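Swapping a Benzyl for a Carbamoyl on a Ring Nitrogen

This account rests on a few compounds, and the source may have more. Where it says the series, first, only, none or still open, it means among the compounds named here.

Compound 1 `NC(=O)c1c(NC(=O)c2ccccc2Cl)sc2c1CCN(Cc1ccccc1)C2`: 12000 nM
Compound 2 `NC(=O)c1c(NC(=O)c2cccc([N+](=O)[O-])c2)sc2c1CCN(Cc1ccc(Cl)cc1Cl)C2`: 19800 nM

Of the compounds shown here, two have been measured in a functional assay on HL-60 cells (Homo sapiens) for antiproliferative activity, with a stated time of 24 h; on this read-out lower numbers stand for stronger inhibition and higher numbers for weaker inhibition. Compound 1 gives 12000 nM, and compound 2 gives 19800 nM. These two numbers lie within the usual scatter of repeated measurements, so compound 1 cannot be separated from compound 2 on this read-out; both sit in a weak range. Compound 3 `NC(=O)c1c(NC(=O)c2ccccc2Cl)sc2c1CCN(C(=O)Nc1ccccc1Cl)C2` has not yet been measured. It differs from compound 1 in one place: (2-chlorophenyl)carbamoyl in place of benzyl on an amine nitrogen in a ring. Within the data shown here, no pair of measured compounds differing in a single place is available, so there is no measured step to lean on. With both known numbers weak and nothing to guide this particular change, the step of a 1.3-fold higher number from compound 1 to compound 3 (0.10 log units; within the scatter) is expected to stay within the scatter. Compound 3 is therefore estimated at 15000 nM, with a range from 4000 nM to 50000 nM.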

Compound 3, half-maximal inhibitory concentration: 12500 nM
For compound 3 the middle estimate is 1.2-fold (0.08 log units) above the measured one; the range from low to high includes it.
By their numbers in this assay, from the lowest: compounds 1, 3 and 2 (each within the scatter of the next).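

Among these compounds, on the amine nitrogen in the ring, this is the first single change that can be read: in this assay, (2-chlorophenyl)carbamoyl in place of benzyl gives a 1.0-fold higher number from compound 1 to compound 3 (0.02 log units; within the scatter) and leaves the two compounds impossible to tell apart. The entering group has more heavy atoms than benzyl and brings a hydrogen-bond donor and a hydrogen-bond acceptor, yet this exchange produces no measurable difference in the read-out. Nothing measured here speaks to the reason for this outcome.

Still open, going by these compounds, is whether a different group on this nitrogen, such as an amine, a carboxylic acid or a longer alkyl chain, would give a number beyond the scatter. Also open, on these data alone, is whether the same exchange would give a similar result on the rest of compound 2.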